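Hydrazone aryl variation on a shared triazolyl-pyridine ether core

This account rests on a few compounds, and the source may have more. Where it says the series, first, only, none or still open, it means among the compounds named here.

Compound 1 `CN(C)CCn1cnnc1-c1cc(Oc2ccc(NC(=O)N/N=C/c3c(Cl)cccc3Cl)cc2F)ccn1` gives 160 nM in a functional assay on MKN-45 cells (Homo sapiens) for cytotoxicity, read by MTT assay, with a stated time of 72 h; on this read-out lower numbers stand for stronger inhibition and higher numbers for weaker inhibition.
Compound 2 `CN(C)CCn1cnnc1-c1cc(Oc2ccc(NC(=O)N/N=C/c3ccccc3)cc2F)ccn1` gives 2730 nM in this assay.
Compound 3 `CN(C)CCn1cnnc1-c1cc(Oc2ccc(NC(=O)N/N=C/c3cccc(Cl)c3Cl)cc2F)ccn1` gives 51 nM in this assay.

Compound 3 gives the lowest number of the three; its nearest neighbour is compound 1, with a 3.1-fold lower number from compound 1 to compound 3 (0.50 log units; beyond the scatter) separating them, and compound 2 lies furthest off, with a 54-fold lower number from compound 2 to compound 3 (1.73 log units; beyond the scatter). The unmeasured compound 4 `COc1ccc(/C=N/NC(=O)Nc2ccc(Oc3ccnc(-c4nncn4CCN(C)C)c3)c(F)c2)cc1O` keeps the core of compound 3 and differs by 3-hydroxy-4-methoxyphenyl in place of 2,3-dichlorophenyl on a carbon with a double bond to nitrogen.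

Within the data shown here, two measured steps bear on this change. Among the measured compounds shown here, removing both chlorines from the ring gave a 17-fold higher number from compound 1 to compound 2 (1.23 log units; beyond the scatter), and putting two chlorines back in the other arrangement gave a 54-fold lower number from compound 2 to compound 3 (1.73 log units; beyond the scatter); the step from compound 3 to compound 4 likewise removes the chlorines, but replaces them with a hydroxy and a methoxy group, for which no measured pair exists here. Within the three compounds, the phenyl without chlorine is the weakest, and compound 3 and compound 1 both sit well below it. A step beyond the scatter toward a higher number is therefore expected in this assay, closer in size to the loss seen for compound 2 than to a neutral change, so the step from compound 3 to compound 4 is estimated at a 16-fold higher number from compound 3 to compound 4 (1.20 log units; beyond the scatter). Compound 4 is expected to give about 800 nM in this assay, with a range from 150 nM to 5000 nM.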

Compound 4, half-maximal inhibitory concentration: 2510 nM
Estimate against measurement, compound 4: 3.1-fold (0.50 log units) below; measured number inside the range.
By their numbers in this assay, from the lowest: compound 3; then compound 1; then compounds 4 and 2 (each within the scatter of the next).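

In this assay the 3-hydroxy-4-methoxyphenyl group on a carbon with a double bond to nitrogen cannot be told apart from plain phenyl, the step being a 1.1-fold lower number from compound 2 to compound 4 (0.04 log units; within the scatter) and so showing that this pair of oxygen substituents on the ring does not reproduce what the chlorines give. Against the chlorinated rings the separation is large in both cases, with a 49-fold higher number from compound 3 to compound 4 (1.69 log units; beyond the scatter) and with a 16-fold higher number from compound 1 to compound 4 (1.20 log units; beyond the scatter) as well. Among the four compounds, then, substitution of the ring is not enough in itself: only the 2,3-dichlorophenyl and 2,6-dichlorophenyl groups stand apart from phenyl, and no compound shown goes against this.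

Still open, going by these compounds, is whether a single chlorine, a hydroxy or a methoxy group alone, or an amine or a carboxylic acid on the same ring would fall with the dichlorophenyl compounds or with compound 2 and compound 4. Nothing shown here accounts for the size of these steps, as no supporting measurement bears on them.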